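Acyl sulfamate adenosine series: thiazolidine in place of valine

This account rests on a few compounds, and the source may have more. Where it says the series, first, only, none or still open, it means among the compounds named here.

Three compounds carry the same adenine-bearing sulfamate and differ only in the acyl group on the sulfamide nitrogen. In a functional assay on PBMC cells (Homo sapiens) for inhibition (a higher number here means a weaker inhibitor, a lower number a stronger inhibitor), compound 1 `CSCC[C@H](N)C(=O)NS(=O)(=O)OC[C@H]1OC[C@@H](n2cnc3c(N)ncnc32)C[C@@H]1O` gives 5500 nM. Compound 3 `C[C@H](N)C(=O)NS(=O)(=O)OC[C@H]1OC[C@@H](n2cnc3c(N)ncnc32)C[C@@H]1O` gives 5500 nM, and compound 2 `CC(C)[C@H](N)C(=O)NS(=O)(=O)OC[C@H]1O[C@@H](n2cnc3c(N)ncnc32)[C@H](O)[C@@H]1O` gives 5600 nM. The three values sit together within the scatter, so compound 2 stands level with compound 1 and compound 3 rather than apart from them.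

Compound 4 `Nc1ncnc2c1ncn2[C@@H]1O[C@H](COS(=O)(=O)NC(=O)[C@@H]2CSCN2)[C@@H](O)[C@H]1O` keeps the sugar of compound 2 and changes the acyl group: 1,3-thiazolidin-4-yl in place of 1-amino-2-methylpropyl on a carbonyl carbon. Among the measured compounds shown here, the one measured step that bears on the acyl group, no change at the digits printed from compound 1 to compound 3 (within the scatter), is flat. For the measured compounds named here, it exchanges a side chain but keeps the amine, whereas the change to compound 4 folds the amine into a ring; no measured step covers that, so the expectation rests on the flat step alone and is held loosely.

Compound 4 is therefore expected to show a 1.2-fold higher number from compound 2 to compound 4 (0.06 log units; within the scatter) in this assay, with no movement beyond the scatter. The estimate for compound 4 is 6500 nM, within a range of 2500 nM to 17000 nM.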

Compound 4, half-maximal inhibitory concentration: 550 nM
The estimate for compound 4 lay 12-fold (1.07 log units) above the measured number; measured number below the stated range.
By their numbers in this assay, from the lowest: compound 4; then compounds 1, 3 and 2 (each within the scatter of the next).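

In this assay the acyl position on the carbonyl carbon proves responsive to the group it carries: a 10-fold lower number from compound 2 to compound 4 (1.01 log units; beyond the scatter), with 1,3-thiazolidin-4-yl in place of 1-amino-2-methylpropyl. The earlier step, no change at the digits printed from compound 1 to compound 3 (within the scatter), exchanged one open side chain for another with the amine left outside any ring, so the flat result there does not extend to a change that brings the amine into a five-membered non-aromatic ring. The heavy-atom number of the group stays the same across compound 2 and compound 4, so the step goes with a change in the kind of group and not in its overall size, though no measurement on hand gives a cause for it.

The compounds shown leave open whether the ring or the sulfur goes with the step; a pyrrolidin-2-yl group, which keeps the ring and the amine but has a carbon in place of the sulfur, would separate the two on the sugar of compound 2. Also open, on these data alone, is whether 1,3-thiazolidin-4-yl gives a similar step on the different sugar carried by compound 1 and compound 3.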